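A few compounds are considered here, and "the series" means these few. Any claim that something is new, unique, unknown or untested is made for them only; others in the source may bear on it.

Working notes on the bis(trifluoromethyl)benzenesulfonamide series, all run in a functional assay on A2780 cells (Homo sapiens) for inhibition, read by MTT assay, with a stated time of 72 h; on this read-out higher numbers stand for weaker inhibition of growth and lower numbers for stronger inhibition of growth. Compound 1 `O=S(=O)(NCCCCNCc1ccc(Br)cc1)c1cc(C(F)(F)F)cc(C(F)(F)F)c1` gives 2100 nM. Compound 2 `O=S(=O)(NCCCNCc1ccccc1)c1cc(C(F)(F)F)cc(C(F)(F)F)c1` gives 4900 nM, the highest number of the three measured. Compound 3 `O=S(=O)(NCCCNCc1ccc(-c2ccccc2)cc1)c1cc(C(F)(F)F)cc(C(F)(F)F)c1` gives 2600 nM. Of the two steps that reach compound 2, the step of a 2.3-fold higher number from compound 1 to compound 2 (0.37 log units; beyond the scatter) lies beyond the scatter, whereas the step of a 1.9-fold lower number from compound 2 to compound 3 (0.28 log units; within the scatter) lies within it; compound 2 therefore stands at the weak end of the set, separated clearly only from compound 1.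

Compound 4 `COc1ccccc1CNCCCNS(=O)(=O)c1cc(C(F)(F)F)cc(C(F)(F)F)c1` awaits measurement. Relative to compound 2 the change is methoxy in place of hydrogen on an aromatic carbon. Both measured steps bear on it, since each alters a substituent on the same benzyl ring while the rest of the molecule is held fixed. The bromine removal raised the number modestly, and the phenyl addition lowered it by an amount inside the scatter. Both point the same way: a substituent on that ring gives a number no higher, and perhaps somewhat lower, than the bare benzyl of compound 2. A methoxy is a small addition, so a modest step downward or none beyond the scatter is expected.

Compound 4 is accordingly estimated at 3500 nM, with a range from 1500 nM to 8000 nM. The expected step from compound 2 to compound 4 is a 1.4-fold lower number from compound 2 to compound 4 (0.15 log units; within the scatter), likely within the scatter.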

Compound 4, concentration for 50% growth inhibition: 1500 nM
Compound 4: middle estimate off by 2.3-fold (0.37 log units), on the high side; the range from low to high includes it.
By their numbers in this assay, from the lowest: compounds 4, 1, 3 and 2 (each within the scatter of the next, the first and the last beyond it).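

In this assay, methoxy in place of hydrogen on an aromatic carbon, ortho to a large group, gives a 3.3-fold lower number from compound 2 to compound 4 (0.51 log units; beyond the scatter) and so provides a single-substituent step on the benzyl ring of compound 2 that lies beyond the scatter, which the phenyl step, a 1.9-fold lower number from compound 2 to compound 3 (0.28 log units; within the scatter), did not provide at its own place. An entering group of only 2 heavy atoms is therefore enough to move the number clearly at this position. Compound 1 differs from compound 4 in both the chain and the ring substituent, so a 1.4-fold lower number from compound 1 to compound 4 (0.15 log units; within the scatter) does not separate those two changes, and nothing measured in the series gives a reason for the methoxy step.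

Open, going by these compounds, is whether this step belongs to this place on the ring or to methoxy wherever it sits, and whether a hydroxy or an ethoxy group at the same place would give a similar number. Also open, on these data alone, is whether the 2-methoxybenzyl group would keep its step on the chain of compound 1.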